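Naphthyl to chlorophenyl exchange on the amine-side arm

The source may report more compounds than this note shows. Statements on the series, on what has been measured and on what is new or still open speak of the compounds shown alone.

Measured so far:
- compound 1 `O=S(=O)(NCCCNCc1cccc2ccccc12)c1cc(C(F)(F)F)cc(C(F)(F)F)c1` — in a functional assay on MCF7 cells (Homo sapiens) for inhibition, read by MTT assay, with a stated time of 72 h (a lower number here means a stronger inhibitor of growth, a higher number a weaker inhibitor of growth), compound 1 gives 1400 nM
- compound 2 `O=S(=O)(NCCCNCc1ccccc1Cl)c1cc(C(F)(F)F)cc(C(F)(F)F)c1` — in this assay compound 2 gives 8800 nM

Compound 2 holds the highest number of the two, the step of a 6.3-fold higher number from compound 1 to compound 2 (0.80 log units; beyond the scatter) setting it apart from compound 1. Compound 3 `O=S(=O)(NCCCNCc1ccc(Cl)c(C(F)(F)F)c1)c1cc(C(F)(F)F)cc(C(F)(F)F)c1` is not yet measured; it differs from compound 2 by 4-chloro-3-(trifluoromethyl)phenyl in place of 2-chlorophenyl on a saturated chain carbon bound to an amine nitrogen. Within the data shown here, the only measured step bears on this change indirectly: it also swaps the aryl group on the saturated chain carbon bound to the amine nitrogen, and a 6.3-fold higher number from compound 1 to compound 2 (0.80 log units; beyond the scatter) shows that such a swap can move the number by a modest amount. With a single step as precedent and no direct pairing, the expectation for compound 3 is a move back toward the number of compound 1, so a modest decrease, a 2.2-fold lower number from compound 2 to compound 3 (0.34 log units; beyond the scatter), is estimated. Compound 3 is therefore expected to give about 4000 nM, with a range from 1400 nM to 12000 nM.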

Compound 3, concentration for 50% growth inhibition: 3500 nM
The estimate for compound 3 lay 1.1-fold (0.06 log units) above the measured number; the measured number falls inside the stated range.
By their numbers in this assay, from the lowest: compound 1; then compound 3; then compound 2.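

In this assay, the aryl group on a saturated chain carbon bound to an amine nitrogen can also shift the number downward: 4-chloro-3-(trifluoromethyl)phenyl in place of 2-chlorophenyl gives a 2.5-fold lower number from compound 2 to compound 3 (0.40 log units; beyond the scatter). Replacing naphthalen-1-yl with the same group still gives a 2.5-fold higher number from compound 1 to compound 3 (0.40 log units; beyond the scatter), so this substituted phenyl recovers part of the rise seen with 2-chlorophenyl but not all of it, and compound 3 falls between the other two. Nothing measured here accounts for these steps, and the contributions of the trifluoromethyl and of the chlorine location cannot be separated.

Open, from the compounds shown here alone, is whether the trifluoromethyl alone carries the step from 2-chlorophenyl. Also open, going by these compounds, is how a pyridine ring or a carboxylic acid on the aryl ring would read, and whether any aryl group here would surpass compound 1 at 1400 nM.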